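Adding Chloro to the Core of Compound 2

The source may hold more compounds than are shown below. What is called first, only, known or untested is meant among the compounds shown, and "the series" means these compounds.

Measured compounds and their values in a functional assay (aorta) with Rattus norvegicus as the target; on this read-out higher numbers stand for an effect only at larger amounts of compound and lower numbers for an effect already at smaller amounts:
compound 1 `CCC(C)NC1=NS(=O)(=O)c2cccnc2N1` gives 50.9 uM
compound 2 `C[C@@H](NC1=NS(=O)(=O)c2cccnc2N1)C1CCCCC1` gives 25.2 uM
compound 3 `CCC(C)NC1=NS(=O)(=O)c2cc(Cl)cnc2N1` gives 20 uM

Compound 1 and compound 3 share a core and differ only by the change (chloro in place of hydrogen on an aromatic carbon). This single change produced the step of a 2.5-fold lower number from compound 1 to compound 3 (0.41 log units; beyond the scatter).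

Compound 2 carries a different side chain on the same kind of core; how its core differs from that of compound 1 is not broken down here. Compound 4 `C[C@@H](NC1=NS(=O)(=O)c2cc(Cl)cnc2N1)C1CCCCC1` is not yet measured. It stands to compound 2 as compound 3 stands to compound 1: the change (chloro in place of hydrogen on an aromatic carbon), the same change as before, since both take place at the same position.

In this assay the step from compound 2 to compound 4 is expected to be about a 2.3-fold lower number from compound 2 to compound 4 (0.36 log units; beyond the scatter), because the earlier step of a 2.5-fold lower number from compound 1 to compound 3 (0.41 log units; beyond the scatter) showed what this change did on the neighbouring pair. The estimate for compound 4 is therefore 11 uM, expected to lie between 5 uM and 24 uM.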

Compound 4, concentration for half-maximal effect: 3.5 uM
For compound 4 the middle estimate is 3.1-fold (0.50 log units) above the measured one; measured number outside the range, below it.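

In this assay, putting chloro in place of hydrogen on the aromatic carbon gave a 7.2-fold lower number from compound 2 to compound 4 (0.86 log units; beyond the scatter), so compound 4 acts at smaller amounts than compound 2. The change pointed the same way on both cores, but its size did not carry over unchanged: the same change on two cores in this assay, a 2.5-fold lower number (0.41 log units; beyond the scatter) from compound 1 to compound 3 and a 7.2-fold lower number (0.86 log units; beyond the scatter) from compound 2 to compound 4, 2.8-fold (0.45 log units) apart, beyond the scatter of two such steps With only these two pairs, the data show that the side chain can go along with a different size of step, but they do not show why, nor do they give a rule for how large the step would be on any further core in this series.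

The compounds shown have only hydrogen or chloro at this ring position, so it remains open whether fluoro, bromo or a methyl group there would give a similar step. As far as these compounds go, it is also open how the chloro step would behave alongside other side chains, such as a longer chain or one carrying an amine.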